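This account rests on a few compounds, and the source may have more. Where it says the series, first, only, none or still open, it means among the compounds named here.

In an ADME assay on L6 cells (Rattus norvegicus) for cytotoxicity (a higher number here means a weaker inhibitor, a lower number a stronger inhibitor), compound 1 `N#Cc1ccccc1N1CCN(C(=O)Cn2cnc([N+](=O)[O-])n2)CC1` gives 213000 nM, compound 2 `Cc1ccc(N2CCN(C(=O)Cn3cnc([N+](=O)[O-])n3)CC2)cc1` gives 148000 nM and compound 3 `O=C(Cn1ccnc1[N+](=O)[O-])N1CCN(c2ncccn2)CC1` gives 280000 nM. Compound 2 lies within the scatter of both other compounds, so these numbers do not separate it from either of them.

Compound 4 `O=C(Cn1cnc([N+](=O)[O-])n1)N1CCN(c2ccccn2)CC1` has not yet been measured. Compared with compound 2, it carries pyridin-2-yl in place of 4-methylphenyl on an amine nitrogen in a ring, with pyridin-2-yl in place of 4-methylphenyl on an amine nitrogen in a ring.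

For the measured compounds named here, only one measured step bears directly on this change. It is a 1.4-fold lower number from compound 1 to compound 2 (0.16 log units; within the scatter), which exchanges one group for another at the same nitrogen and stays within the scatter. Compound 3, at 280000 nM, differs from compound 2 in more than one place and so offers only a loose reference. No step beyond the scatter is therefore expected in this assay, and no direction is firmly indicated.

The expected change is small, an estimated 1.4-fold higher number from compound 2 to compound 4 (0.13 log units; within the scatter). Compound 4 is expected at about 200000 nM, with an estimated range of 110000 nM to 350000 nM.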

Compound 4, half-maximal inhibitory concentration: 173000 nM
Beside the measured number, compound 4's estimate is 1.2-fold (0.06 log units) above it, within the range that was stated.
By their numbers in this assay, from the lowest: compounds 2, 4, 1 and 3 (each within the scatter of the next).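

At this amine nitrogen in a ring, this assay now covers an aromatic ring with a hetero atom as well as rings of carbon only, and it does not separate them: the steps are a 1.2-fold higher number from compound 2 to compound 4 (0.07 log units; within the scatter) and a 1.2-fold lower number from compound 1 to compound 4 (0.09 log units; within the scatter), both within the scatter. Pyridin-2-yl brings a hydrogen-bond acceptor that 4-methylphenyl lacks, yet the numbers for this exchange cannot be told apart. Nothing available explains why these values sit so close together.

As far as these compounds go, whether a different kind of group on this nitrogen, such as an aliphatic amine, a carboxylic acid or a longer alkyl chain, would take the number beyond the scatter remains open. From the compounds shown here alone, it is also open whether pyridin-2-yl would behave the same way on the core of compound 3.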